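The source may report more compounds than this note shows. Statements on the series, on what has been measured and on what is new or still open speak of the compounds shown alone.

Measured compounds:
- Compound 1, `CCN(CC)c1cc2[nH]c(C3CCCCC3)nc2cc1NC(=O)OCCOCCOC`. In an ADME assay on Vero cells (Chlorocebus sabaeus) for cytotoxicity, read by resazurin assay, with a stated time of 3 days (a higher number here means a weaker inhibitor, a lower number a stronger inhibitor), compound 1 gives > 100 ug/mL, which is a limit of the assay and not a number.
- Compound 2, `CN(C)c1cc2[nH]c(C3CCCCC3)nc2cc1NC(=O)c1cccs1`. In this assay compound 2 gives > 100 ug/mL, again a limit.
- Compound 3, `CCCCOC(=O)Nc1cc2nc(C3CCCCC3)[nH]c2cc1N(C)CCN(C)C`. In this assay compound 3 gives > 100 ug/mL, also a limit.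

Within the data shown here, compound 1 therefore stands at a limit only, and the two further values shown are limits as well, so none of the three can be placed relative to another and no step between measured compounds can be read. The one shared observation is the limit of > 100 ug/mL in this assay, at which 3 of the 3 values shown sit.

Compound 4, `CCCOCC(=O)Nc1cc2nc(C3CCCCC3)[nH]c2cc1N(CC)CC`, has not yet been measured in this assay. It differs from compound 1 in a single place: propoxymethyl in place of 2-(2-methoxyethoxy)ethoxy on a carbonyl carbon. The amide-type nitrogen and the shared core carry over unchanged.

Among the measured compounds shown here, with every value so far sitting at the limit, no step beyond the scatter is expected in either direction; the expected step is a step that the limit leaves unreadable from compound 1 to compound 4. Compound 4 is accordingly estimated at 110 ug/mL, with a range from 50 ug/mL to 250 ug/mL, and the likelier outcome is that the assay once more reports a limit rather than a number.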

Compound 4, half-maximal inhibitory concentration: > 100 ug/mL
Compound 4 was reported as a limit; the forecaster's own chance of this, stated with the estimate: 75%; the middle value lies beyond the limit too.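

In this assay compound 4 gives > 100 ug/mL, which is a limit and not a number. No step from compound 1 to compound 4 can be read, as both stand at a limit: the limit of > 100 ug/mL in this assay, at which 4 of the 4 values shown sit.

The compounds shown leave open how the four differ in this assay, and which change on the shared core, if any, would yield a measured number.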